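The compounds below may be only part of what the source reports. "The series", "measured", "known", "first", "only" and "open" are said of these compounds alone.

Working notes on the series. Compound 1 `CCCC(=O)C1=C(C)NC(=O)NC1c1ccco1` serves as the reference point; in an assay on membranes from HEK293 cells for displacement of a labelled ligand from adenosine receptor A2b (Homo sapiens), read by scintillation counting, with a stated time of 30 min (a lower number here means a stronger inhibitor, a higher number a weaker inhibitor), compound 1 gives 807 nM. That is the second highest of the three numbers recorded so far, though all three lie within the scatter of one another: compound 3 `CC1=C(c2ncc(C)o2)C(c2ccco2)NC(=O)N1` gives 905 nM in this assay, and compound 2 `CC1=C(C(=O)SC(C)C)C(c2ccoc2)NC(=O)N1` gives 637 nM. Among the measured compounds shown here, the only single-point step available, a 1.1-fold higher number from compound 1 to compound 3 (0.05 log units; within the scatter), replaces the group on the double-bonded ring carbon without moving the number. Compound 2 differs from compound 1 in more than one place, so nothing beyond the two values themselves can be said of that pair.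

Compound 4 `CC1=C(C(=O)OC2CCC2)C(c2ccco2)NC(=O)N1` carries the change (cyclobutyloxy in place of propyl on a carbonyl carbon). For the measured compounds named here, no measured step alters exactly this part of compound 1. Going by the values given here, the one step that is measured stayed within the scatter, and compound 2, which also varies what the carbonyl carbon bears, gives a number close to that of compound 1. The expected step of a 1.1-fold lower number from compound 1 to compound 4 (0.03 log units; within the scatter) is therefore none beyond the scatter. Compound 4 is estimated at 750 nM in this assay, within a range of 300 nM to 1900 nM.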

Compound 4, inhibition constant: 95.1 nM
The estimate for compound 4 lay 7.9-fold (0.90 log units) above the measured number; the whole stated range lies above it.
By their numbers in this assay, from the lowest: compound 4; then compounds 2, 1 and 3 (each within the scatter of the next).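

In this assay, among the compounds shown here, an 8.5-fold lower number from compound 1 to compound 4 (0.93 log units; beyond the scatter) is the first step to lie beyond the scatter, with cyclobutyloxy in place of propyl on a carbonyl carbon. It shows that what this carbonyl carbon bears can move the number, which the replacement of the whole group on the double-bonded ring carbon, a 1.1-fold higher number from compound 1 to compound 3 (0.05 log units; within the scatter), did not show. Nothing on hand offers a reason for this step.

The compounds shown do not tell whether the step goes with the added oxygen or with the four-membered ring, as a propyloxy or a cyclobutyl group on this carbonyl carbon lies outside them. Going by these compounds, how an amine or a longer chain on the same carbonyl carbon would read also remains open.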